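Chloro Addition on Two Related Cores in Paw Edema Inhibition

A few compounds are considered here, and "the series" means these few. Any claim that something is new, unique, unknown or untested is made for them only; others in the source may bear on it.

Compound 1, `O=C(CSc1nc(-c2ccccc2)c(C(=O)O)c(=O)[nH]1)Nn1c(COc2ccc(Cl)cc2Cl)nc2ccccc2c1=O`: 69.1%
Compound 2, `O=C(CSc1nc(-c2ccc(Cl)cc2)c(C(=O)O)c(=O)[nH]1)Nn1c(COc2ccc(Cl)cc2Cl)nc2ccccc2c1=O`: 58.2%
Compound 3, `N#Cc1c(Nc2ccccc2)nc(SCC(=O)Nn2c(COc3ccc(Cl)cc3Cl)nc3ccccc3c2=O)nc1-c1ccc(Cl)cc1`: 43.6%

All three were tested in a functional assay on the whole organism (strain albino) for inhibition, with Rattus norvegicus as the target, read by paw edema, with a stated time of 1 h, at a dose of 100 mg/kg by the oral route; on this read-out lower numbers stand for less inhibition and higher numbers for more inhibition at the one dose given (going by the name of the read-out). Compound 2 differs from compound 1 only by chloro in place of hydrogen on an aromatic carbon, and this change gave a number 10.9 percentage points lower from compound 1 to compound 2 (beyond the scatter). Compound 3 rests on a different core; the difference between the cores of compound 1 and compound 3 is not broken down here. Compound 3 gives the lowest of the three numbers, beyond the scatter from both others.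

Compound 4, `N#Cc1c(Nc2ccc(Cl)cc2)nc(SCC(=O)Nn2c(COc3ccc(Cl)cc3Cl)nc3ccccc3c2=O)nc1-c1ccc(Cl)cc1`, has not yet been measured. It differs from compound 3 by chloro in place of hydrogen on an aromatic carbon, the same change that separates compound 1 and compound 2. For compound 4 a step of a number 8.6 percentage points lower from compound 3 to compound 4 (within the scatter) is expected, because the same change produced a number 10.9 percentage points lower from compound 1 to compound 2 (beyond the scatter). Compound 4 is therefore estimated at 35%, likely between 22% and 50%.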

Compound 4, a percentage reported as inhibition, in the whole organism at one dose (the size of the read-out at that dose, not a potency): 54.6%
The estimate for compound 4 lay 19.6 percentage points below the measured number; the measured number lies above the stated range.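

On the core of compound 3, chloro in place of hydrogen on an aromatic carbon gave a number 11 percentage points higher from compound 3 to compound 4 (beyond the scatter) in this assay. Set beside the earlier step, the direction of this change did not carry from one core to the other: the same change on two cores in this assay, a number 10.9 percentage points lower (beyond the scatter) from compound 1 to compound 2 and a number 11 percentage points higher (beyond the scatter) from compound 3 to compound 4, 21.9 percentage points apart, beyond the scatter of two such steps This does not show why, and with only one pair on each core, the core cannot be separated from the place of the chloro, which here enters on the anilino group that compound 1 lacks.

As far as these compounds go, it remains open whether a fluoro or a methoxy group on that anilino ring would move the number the same way as chloro. From the compounds shown here alone, it also remains open how chloro would act on the phenyl group of compound 3.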